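A few compounds are considered here, and "the series" means these few. Any claim that something is new, unique, unknown or untested is made for them only; others in the source may bear on it.

Three compounds have numbers in an assay on HEK293 cells for agonist activity at transient receptor potential cation channel subfamily M member 8 (Homo sapiens), read by fluorescence and calcium flux, with a stated time of 15 min; on this read-out lower numbers stand for an effect already at smaller amounts and higher numbers for an effect only at larger amounts of compound. Compound 1 `CCN(Cc1cccs1)C(=O)COc1ccccc1` gives 1400 nM. Compound 2 `CCC(C)N(Cc1cccs1)C(=O)COc1ccc(C)cc1` gives 2000 nM, the highest of the three; its number and that of compound 1 lie within the scatter of each other, so the two cannot be told apart. Compound 3 `COc1ccc(OCC(=O)N(Cc2cccs2)c2ccn[nH]2)cc1` gives 3.7 nM, a far lower number than compound 2, a gap well beyond the scatter. The unmeasured compound 4 `COCCN(Cc1cccs1)C(=O)COc1ccc(C)cc1` differs from compound 2 in one place: 2-methoxyethyl in place of sec-butyl on an amide-type nitrogen. Within the data shown here, no step between measured compounds traces such a change, so the expectation rests on the whole set. Compounds 1 and 2 give numbers within the scatter of each other, and compound 4 keeps the rest of compound 2 unchanged; on that basis the step of a 1.3-fold lower number from compound 2 to compound 4 (0.12 log units; within the scatter) is expected to be small, not clearly beyond the scatter in either direction. Compound 4 is therefore estimated at 1500 nM, with a range from 500 nM to 5000 nM.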

Compound 4, half-maximal effective concentration: 400 nM
Estimate against measurement, compound 4: 3.8-fold (0.57 log units) above, and the stated range ends above it.
By their numbers in this assay, from the lowest: compound 3; then compound 4; then compounds 1 and 2 (each within the scatter of the next).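

In this assay, among these compounds, placing 2-methoxyethyl instead of sec-butyl on the amide-type nitrogen gives a 5.0-fold lower number from compound 2 to compound 4 (0.70 log units; beyond the scatter) and so provides the first direct evidence that the number responds to a change at this position. The two groups have the same count of heavy atoms, but the entering group has one oxygen in place of a carbon and one hydrogen-bond acceptor where the leaving group has none. Nothing available accounts for the step or ties it to any one of these differences.

The compounds shown leave open whether the oxygen itself matters, since this single pair cannot separate it from the change in chain shape, and a 2-hydroxyethyl or a 2-aminoethyl group would test the position further. They also leave open whether a longer chain, such as 3-methoxypropyl, would carry the number further in either direction.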